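Swapping the Octyl Chain for a Bromophenyl Ring

The compounds below may be only part of what the source reports. "The series", "measured", "known", "first", "only" and "open" are said of these compounds alone.

Within the data shown here, in a functional assay on MOLT-4 cells (Homo sapiens) for antiproliferative activity, read by MTT assay, with a stated time of 3 days (a higher number here means a weaker inhibitor, a lower number a stronger inhibitor), compound 2 `CCCCCCCCC#Cc1cn(C/C=C\CN2C(=O)c3ccccc3C2=O)c(=O)[nH]c1=O` gives 36000 nM, the lower of the two numbers measured so far. Compound 1 `Cc1ccc(C#Cc2cn(C/C=C\CN3C(=O)c4ccccc4C3=O)c(=O)[nH]c2=O)cc1` gives 266000 nM in this assay, and the step of a 7.4-fold lower number from compound 1 to compound 2 (0.87 log units; beyond the scatter) shows the octyl chain giving a clearly lower number than the 4-methylphenyl group. Compound 3 `O=C1c2ccccc2C(=O)N1C/C=C\Cn1cc(C#Cc2ccc(Br)cc2)c(=O)[nH]c1=O` carries the change (4-bromophenyl in place of octyl on a triple-bonded carbon), bringing an aromatic ring back in place of the chain. Because the earlier step of a 7.4-fold lower number from compound 1 to compound 2 (0.87 log units; beyond the scatter) favoured the chain, compound 3 is expected to give a higher number, estimated at 200000 nM with a range from 60000 nM to 500000 nM, a step of a 5.6-fold higher number from compound 2 to compound 3 (0.74 log units; beyond the scatter).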

Compound 3, half-maximal inhibitory concentration: 89000 nM
Compound 3: the middle estimate sits 2.2-fold (0.35 log units) above what was measured; low and high end bracket the measured number.
By their numbers in this assay, from the lowest: compound 2; then compound 3; then compound 1.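

In this assay, the aromatic ring on the triple-bonded carbon does not fix the result, since bromo in place of methyl on an aromatic carbon gives a 3.0-fold lower number from compound 1 to compound 3 (0.48 log units; beyond the scatter). What the ring carries therefore changes the number. Even so, the octyl chain keeps the lowest number, with a 2.5-fold higher number from compound 2 to compound 3 (0.39 log units; beyond the scatter), so this bromophenyl ring recovers only part of the gap to the chain. Going by these compounds, whether a longer chain, or a phenyl ring carrying an amine or a carboxylic acid, would fall below compound 2 remains open. No measurement here explains these differences.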